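The source may hold more compounds than are shown below. What is called first, only, known or untested is meant among the compounds shown, and "the series" means these compounds.

Measured so far in a physicochemical assay for lipophilicity, read by spectrophotometry, using the shake flask method, measured as octanol-water partition; on this read-out higher numbers stand for higher lipophilicity and lower numbers for lower lipophilicity: compound 1 `N#Cc1ccc(C(F)F)cc1`, 1.75; compound 2 `Cc1ccc(C(F)F)cc1`, 2.94; compound 3 `FC(F)OCCc1ccccc1`, 3.16.

Compound 3 gives the highest of the three numbers, although compound 2 lies within the scatter of it; compound 1 lies clearly lower. Within the data shown here, the single measured step, a number 1.19 log units higher from compound 1 to compound 2 (beyond the scatter), concerns an exchange on an aromatic carbon and has no direct bearing on compound 4 `FC(F)CCc1ccccc1`, which differs from compound 3 by difluoromethyl in place of difluoromethoxy on a saturated chain carbon, two bonds along the chain from an aromatic carbon. Among the measured compounds shown here, no measured step covers this exchange of a difluoromethoxy for a difluoromethyl group on the chain. For compound 4 a step of modest size, if any beyond the scatter, is expected in this assay, a number 0.14 log units higher from compound 3 to compound 4 (within the scatter). Compound 4 is therefore estimated at 3.3, within a range from 2.8 to 3.8.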

Compound 4, partition coefficient: 3.02
For compound 4 the middle estimate is 0.28 log units above the measured one; low and high end bracket the measured number.
By their numbers in this assay, from the lowest: compound 1; then compounds 2, 4 and 3 (each within the scatter of the next).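

In this assay the exchange of difluoromethoxy for difluoromethyl on a saturated chain carbon, two bonds along the chain from an aromatic carbon, gives a number 0.14 log units lower from compound 3 to compound 4 (within the scatter) and so no difference that stands clear of the scatter. At this position, the hydrogen-bond acceptor counted in the group that leaves can go without a step beyond the scatter. Nothing at hand explains this result.

From the compounds shown here alone, whether an amine or a carboxylic acid on this chain would behave alike stays open. So does whether the same exchange on a longer chain or on an aromatic carbon would give a similar step.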